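Urea series: fluorine pattern on the aryl amide nitrogen

The source may hold more compounds than are shown below. What is called first, only, known or untested is meant among the compounds shown, and "the series" means these compounds.

Measured so far:
compound 1 `CC(C)(C)c1cc(NC(=O)Nc2ccc(F)cc2)n(-c2ccccc2)n1`: 7.4 degrees C
compound 2 `CC(C)(C)c1cc(NC(=O)Nc2cc(C(F)(F)F)cc(C(F)(F)F)c2)n(-c2ccc(Br)cc2)n1`: 0.1 degrees C

In an assay on isolated protein for inhibition of STE20-like serine/threonine-protein kinase (Homo sapiens), read by thermal shift assay, tested at 10 uM (on this read-out lower numbers stand for weaker stabilisation of the target and higher numbers for stronger stabilisation of the target against heat), compound 1 gives 7.4 degrees C, the higher of the two numbers. Compound 2 gives 0.1 degrees C, a gap beyond the scatter, but compound 2 also differs at the aryl on the core nitrogen, so no single change is isolated. Compound 3 `CC(C)(C)c1cc(NC(=O)Nc2cc(F)cc(F)c2)n(-c2ccccc2)n1` carries 3,5-difluorophenyl in place of 4-fluorophenyl on an amide-type nitrogen. Among the measured compounds shown here, no measured pair shows this change alone. The step from compound 1 is expected to be a modest loss a number 1.9 degrees C lower from compound 1 to compound 3 (beyond the scatter) in this assay. Compound 3 is estimated to give 5.5 degrees C, between 2.5 degrees C and 8.5 degrees C.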

Compound 3, shift of the target's melting temperature: 3 degrees C
Compound 3: the middle estimate sits 2.5 degrees C above what was measured; low and high end bracket the measured number.
By their numbers in this assay, from the lowest: compound 2; then compound 3; then compound 1.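

In this assay, among the compounds shown here, 3,5-difluorophenyl in place of 4-fluorophenyl on an amide-type nitrogen gives a number 4.4 degrees C lower from compound 1 to compound 3 (beyond the scatter) and is the first change isolated at a single place. The substitution pattern of this aryl therefore affects the read-out on its own, with the rest of compound 1 unchanged. No measurement shown bears on the reason for this step.

As far as these compounds go, whether the loss follows from the added fluorine or from the changed fluorine pattern stays open. A 3-fluorophenyl or a plain phenyl on this nitrogen would separate the two.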